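This account rests on a few compounds, and the source may have more. Where it says the series, first, only, none or still open, it means among the compounds named here.

Going by the values given here, in a functional assay on HEK293 cells for agonist activity at D(4) dopamine receptor (Homo sapiens), read by FLIPR (on this read-out higher numbers stand for larger maximal responses and lower numbers for smaller maximal responses), compound 2 `O=C(CN1CCC(c2cccc[n+]2[O-])CC1)NC1CCCCC1` gives 58%, the higher of the two numbers measured so far; compound 1 `COc1ccccc1C1CCN(CC(=O)Nc2cccc(C)c2)CC1` gives 43% in this assay, a gap beyond the usual scatter. Compound 3 `Cc1cccc(C)c1NC(=O)CN1CCC(c2cccc[n+]2[O-])CC1` is not yet measured and differs from compound 2 by 2,6-dimethylphenyl in place of cyclohexyl on an amide-type nitrogen. Among the compounds with values here, no measured pair differs in only this one place, so the step cannot be read off directly. Within the data shown here, the only other measured compound, compound 1, gives 43% in this assay, so a modest drop is expected. The expected step is a number 10 percentage points lower from compound 2 to compound 3 (within the scatter). Compound 3 is estimated at 48%, ranging from 30% to 66%.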

Compound 3, largest response reached (reported as efficacy), in percent of the reference or control that the assay uses: 68%
Beside the measured number, compound 3's estimate is 20 percentage points below it, outside the stated range (above it).
By their numbers in this assay, from the lowest: compound 1; then compounds 2 and 3 (each within the scatter of the next).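

In this assay the step is a number 10 percentage points higher from compound 2 to compound 3 (within the scatter) when 2,6-dimethylphenyl replaces cyclohexyl on an amide-type nitrogen. This place therefore holds either a six-membered non-aromatic carbon ring or a six-membered aromatic one, with the two results not separable from the usual scatter. Nothing available explains why the two groups read alike. From the compounds shown here alone, it remains open how plain phenyl, without the two methyl groups, would read at this place. Going by these compounds, a ring carrying an amine or a carboxylic acid, or a simple open chain such as butyl, is equally open.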